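The compounds below may be only part of what the source reports. "The series", "measured", "known", "first", "only" and "open" are said of these compounds alone.

Measured in a functional assay on A549 cells (Homo sapiens) for cytotoxicity, read by MTT assay, with a stated time of 24 h, tested at 20 uM; on this read-out lower numbers stand for a stronger effect and higher numbers for a weaker effect at the one concentration tested:
compound 1 `CCOC(=O)CCC(=O)N1CCN(CCCOc2cc3c(Nc4ccc(F)c(Cl)c4)ncnc3cc2OC)CC1` gives 70%
compound 2 `CCCCCOC(=O)CCC(=O)N1CCN(CCCOc2cc3c(Nc4ccc(F)c(Cl)c4)ncnc3cc2OC)CC1` gives 81.2%
compound 3 `CCCCCCCCCCOC(=O)CCC(=O)N1CCN(CCCOc2cc3c(Nc4ccc(F)c(Cl)c4)ncnc3cc2OC)CC1` gives 88.2%

In this assay compound 3 stands highest of the three numbers, that is, weakest at the one concentration tested. Its gap to compound 2 is within the scatter, while a number 18.2 percentage points higher from compound 1 to compound 3 (beyond the scatter) lies beyond it. Compound 4 `CCCCCCCCCCCOC(=O)CCC(=O)N1CCN(CCCOc2cc3c(Nc4ccc(F)c(Cl)c4)ncnc3cc2OC)CC1` differs from compound 3 by methyl in place of hydrogen on a saturated chain carbon, ten or more bonds along the chain from an oxygen next to a carbonyl group. Going by the values given here, the steps that bear on this all lengthen the same chain: a number 11.2 percentage points higher from compound 1 to compound 2 (beyond the scatter) and a number 18.2 percentage points higher from compound 1 to compound 3 (beyond the scatter) were modest, and a number 7 percentage points higher from compound 2 to compound 3 (within the scatter) was within the scatter although it added far more than a single methyl. A one-carbon lengthening is therefore expected to give no step beyond the scatter, at most a slight rise, so the expected step is a number 0.8 percentage points higher from compound 3 to compound 4 (within the scatter). Compound 4 is estimated at 89%, expected between 80% and 97%.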

Compound 4, a percentage reported as activity, at one concentration (the size of the read-out at that concentration, not a potency): 85.2%
Compound 4: the middle estimate sits 3.8 percentage points above what was measured; the range from low to high includes it.
By their numbers in this assay, from the lowest: compound 1; then compounds 2, 4 and 3 (each within the scatter of the next).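

In (this assay), methyl at this far point of the chain gives no step beyond the scatter (a number 3 percentage points lower from compound 3 to compound 4 (within the scatter)), and the same holds for the longer gap (a number 4 percentage points higher from compound 2 to compound 4 (within the scatter)). Compound 2, compound 3 and compound 4 therefore cannot be told apart, while compound 1, with the shortest chain, remains separate (a number 15.2 percentage points higher from compound 1 to compound 4 (beyond the scatter)). No other measurement bears on this result. On these data alone, it remains open whether an amine or a carboxylic acid at the chain end would shift the number, and whether a longer chain would stay within this band.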